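Trading a Long Ether Side Chain for a Formyl Group

The source may report more compounds than this note shows. Statements on the series, on what has been measured and on what is new or still open speak of the compounds shown alone.

Compound 1, `N#Cc1ccn2c(-c3ccccc3)c(-c3ccccc3)c(Cc3ccccc3)c2c1`, gives 46000 nM in an assay for inhibition of Polyunsaturated fatty acid lipoxygenase ALOX15 (Oryctolagus cuniculus); a lower number here means a stronger inhibitor, a higher number a weaker inhibitor.
Compound 2, `N#Cc1ccn2c(-c3ccccc3)c(-c3ccccc3)c(OCOCc3ccccc3)c2c1`, gives 39000 nM in this assay.
Compound 3, `Cc1ccc(S(=O)(=O)Oc2c(-c3ccccc3)c(-c3ccccc3)n3ccc(C#N)cc23)cc1`, gives 25000 nM in this assay.

All three share one core and differ only in the group on a single aromatic carbon. Compound 2 lies within the scatter of both neighbours: the step of a 1.2-fold lower number from compound 1 to compound 2 (0.07 log units; within the scatter) and the step of a 1.6-fold lower number from compound 2 to compound 3 (0.19 log units; within the scatter) are both too small to count as real change, and the same holds for a 1.8-fold lower number from compound 1 to compound 3 (0.26 log units; within the scatter). Three rather different groups at this position thus leave the number essentially where it was.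

Compound 4, `N#Cc1ccn2c(-c3ccccc3)c(-c3ccccc3)c(C=O)c2c1`, has not yet been measured in this assay. It differs from compound 2 in this way: formyl in place of (benzyloxy)methoxy on an aromatic carbon. Among the measured compounds shown here, the group entering is far smaller than anything tried at this position so far, so none of the measured steps covers quite this change. For the measured compounds named here, still, every step that does touch this position stayed within the scatter, and that is the only guide available.

The number for compound 4 is therefore expected to sit near that of compound 2, meaning an expected step of a 1.0-fold lower number from compound 2 to compound 4 (0.01 log units; within the scatter). The estimate for compound 4 is 38000 nM, with a likely range from 12000 nM to 110000 nM.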

Compound 4, half-maximal inhibitory concentration: 61000 nM
Estimate against measurement, compound 4: 1.6-fold (0.21 log units) below; low and high end bracket the measured number.
By their numbers in this assay, from the lowest: compounds 3, 2, 1 and 4 (each within the scatter of the next, the first and the last beyond it).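

Going from (benzyloxy)methoxy, with 10 heavy atoms, to formyl, with 2 heavy atoms, is the sharpest cut in size at this aromatic carbon so far, yet in this assay the step of a 1.6-fold higher number from compound 2 to compound 4 (0.19 log units; within the scatter) shows no real change, and neither does the step of a 1.3-fold higher number from compound 1 to compound 4 (0.12 log units; within the scatter) from the benzyl compound. So the earlier picture of a flat position now extends to a much smaller group, although the formyl compound also gives the first step here to pass the usual scatter, a 2.4-fold higher number from compound 3 to compound 4 (0.39 log units; beyond the scatter) and even that step is only modest, so the four groups span a narrow range in which only the two ends can be told apart. The data at hand carry no information on why the formyl and ((4-methylphenyl)sulfonyl)oxy compounds differ.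

The compounds shown leave open whether an amine or a carboxylic acid on this aromatic carbon would move the number further than any group here. They also leave open whether replacing the nitrile or either phenyl group on the shared core would matter more than changes at this position.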